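A methyl gives way to nitro

The source may report more compounds than this note shows. Statements on the series, on what has been measured and on what is new or still open speak of the compounds shown alone.

Compound 1 `Cc1cc(C#N)cc(C)c1Oc1cc(Nc2ccc(C#N)cc2)ncc1[N+](=O)[O-]` gives 36100 nM
Compound 2 `Cc1ccc(Nc2cc(Oc3c(C)cc(C#N)cc3C)c([N+](=O)[O-])cn2)cc1` gives 207000 nM

In an ADME assay on MT4 cells (Homo sapiens) for inhibition, read by MTT assay, with a stated time of 5 days (a higher number here means that more compound is tolerated, a lower number that less compound is tolerated), compound 2 stands highest of the two, at 207000 nM against the lower number of compound 1. Compound 3 `Cc1cc(C#N)cc(C)c1Oc1cc(Nc2ccc([N+](=O)[O-])cc2)ncc1[N+](=O)[O-]`, not yet measured, has nitro in place of methyl on an aromatic carbon, para to a large group (nitro in place of methyl on an aromatic carbon). Among the compounds with values here, one measured step bears on this change: methyl in place of cyano on an aromatic carbon (a 5.7-fold higher number from compound 1 to compound 2 (0.76 log units; beyond the scatter)), a modest step beyond the scatter. Compound 3 gives up that methyl, but for nitro rather than cyano, so this is only a loose guide. A step of similar size towards a lower number is therefore expected in this assay for this change. The expected move is (a 5.8-fold lower number from compound 2 to compound 3 (0.76 log units; beyond the scatter)) by this estimate. For compound 3 the estimated value is 36000 nM with an expected range from 10000 nM to 120000 nM around it.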

Compound 3, half-maximal cytotoxic concentration: 141000 nM
For compound 3 the middle estimate is 3.9-fold (0.59 log units) below the measured one; measured number above the stated range.
By their numbers in this assay, from the lowest: compound 1; then compounds 3 and 2 (each within the scatter of the next).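

In this assay nitro in place of methyl on this aromatic carbon, para to a large group, gives a 1.5-fold lower number from compound 2 to compound 3 (0.17 log units; within the scatter) and so leaves the number within the usual scatter, which means that these two groups cannot be told apart here. Nitro in place of cyano at the same carbon gives a 3.9-fold higher number from compound 1 to compound 3 (0.59 log units; beyond the scatter) and this step, like the one from cyano to methyl, lies beyond the scatter. Among these three compounds, then, the cyano compound stands apart, with a lower number than both others, while the methyl and nitro compounds sit together.

From the compounds shown here alone, whether an amine or a carboxylic acid at this carbon would join the methyl and nitro compounds or the cyano compound remains open. Nothing available here speaks to what lies behind these numbers.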